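The compounds below may be only part of what the source reports. "The series", "measured", "known", "first", "only" and "open" are said of these compounds alone.

In an ADME assay on L6 cells (Rattus norvegicus) for cytotoxicity, read by fluorescence and resazurin assay, with a stated time of 72 h (a lower number here means that less compound is tolerated, a higher number that more compound is tolerated), compound 1 `CC(C)c1ccc(-c2c[nH]cc2C(c2ccc(Cl)cc2Cl)n2ccnc2)cc1` gives 12700 nM, compound 2 `COc1ccc(-c2c[nH]cc2C(c2ccc(Cl)cc2Cl)n2ccnc2)cc1` gives 14800 nM and compound 3 `Clc1ccc(C(c2c[nH]cc2-c2ccc(Cl)c3ccccc23)n2ccnc2)c(Cl)c1` gives 4900 nM. Compound 2 therefore lies within the scatter of compound 1, while compound 3 shows a clearly lower number than compound 2. Compound 4 `CSc1ccc(-c2c[nH]cc2C(c2ccc(Cl)cc2Cl)n2ccnc2)cc1` has methylsulfanyl in place of the methoxy of compound 2 on an aromatic carbon (methylsulfanyl in place of methoxy on an aromatic carbon). Within the data shown here, only one measured step bears on this change: a 1.2-fold higher number from compound 1 to compound 2 (0.07 log units; within the scatter), which put methoxy in place of isopropyl and stayed within the scatter. On that evidence, no step beyond the scatter is expected in this assay. The expected change is a 1.1-fold lower number from compound 2 to compound 4 (0.06 log units; within the scatter). Compound 4 is estimated at 13000 nM, with an expected range of 6500 nM to 26000 nM.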

Compound 4, half-maximal cytotoxic concentration: 7220 nM
For compound 4 the middle estimate is 1.8-fold (0.26 log units) above the measured one; measured number inside the range.
By their numbers in this assay, from the lowest: compounds 3, 4, 1 and 2 (each within the scatter of the next, the first and the last beyond it).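

In this assay this position, para to a large group, proved not to be indifferent to every swap: the change gives a 2.0-fold lower number from compound 2 to compound 4 (0.31 log units; beyond the scatter), a modest step only just past the noise. Measured against the isopropyl compound, the same group gives a 1.8-fold lower number from compound 1 to compound 4 (0.25 log units; within the scatter), so only the swap from methoxy registers as a real change. Nothing available here accounts for that difference.

As far as these compounds go, whether an amine, a carboxylic acid or a longer chain on this carbon would move the number stays open, as does whether the methylsulfanyl step would recur on another core.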